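Switching the aminothiazole for imidazole on the S-configured chain

The compounds below may be only part of what the source reports. "The series", "measured", "known", "first", "only" and "open" are said of these compounds alone.

Compound 1, `Cc1nc(N)sc1CCCNC(=N)NC(=O)C[C@@H](C)c1ccccc1`, gives 53.7 nM in an in vitro functional assay on Sf9 cells for agonist activity at histamine H2 receptor (Homo sapiens), read by GTPgammaS binding; on this read-out lower numbers stand for an effect already at smaller amounts and higher numbers for an effect only at larger amounts of compound.
Compound 2, `C[C@H](CC(=O)NC(=N)NCCCc1c[nH]cn1)c1ccccc1`, gives 120 nM in this assay.
Compound 3, `Cc1nc(N)sc1CCCNC(=N)NC(=O)C[C@H](C)c1ccccc1`, gives 28.2 nM in this assay.

Compound 3 holds the lowest number of the three, though its gap to compound 1 stays within the scatter; that pair is separated only by the drawn configuration at the chain stereocentre (the fact that one of compounds 1 and 3 is drawn with a defined configuration and the other without, at the place where they differ), and the step runs a 1.9-fold lower number from compound 1 to compound 3 (0.28 log units; within the scatter). Compound 4, `C[C@@H](CC(=O)NC(=N)NCCCc1c[nH]cn1)c1ccccc1`, is the next candidate. Its change from compound 3 is 1H-imidazol-4-yl in place of 2-amino-4-methyl-1,3-thiazol-5-yl on a saturated chain carbon, three bonds along the chain from an amine nitrogen. Within the data shown here, one measured step bears directly on it: the same ring swap on the other configuration, a 2.2-fold higher number from compound 1 to compound 2 (0.35 log units; beyond the scatter). Compound 2, which already carries the imidazole, gives 120 nM. The expectation for compound 4 is therefore a modest rise in number, a 2.2-fold higher number from compound 3 to compound 4 (0.34 log units; beyond the scatter), roughly matching that earlier swap. Compound 4 is estimated at 62 nM, expected to fall between 30 nM and 130 nM.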

Compound 4, half-maximal effective concentration: 79.4 nM
Compound 4: middle estimate off by 1.3-fold (0.11 log units), on the low side; measured number inside the range.
By their numbers in this assay, from the lowest: compounds 3, 1, 4 and 2 (each within the scatter of the next, the first and the last beyond it).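

The swap to 1H-imidazol-4-yl now gives a rise on the second configuration as well, with a 2.8-fold higher number from compound 3 to compound 4 (0.45 log units; beyond the scatter), so the change at this place no longer rests on a single pair. The two steps agree in direction and their sizes do not separate: the same change on two cores in this assay, a 2.2-fold higher number (0.35 log units; beyond the scatter) from compound 1 to compound 2 and a 2.8-fold higher number (0.45 log units; beyond the scatter) from compound 3 to compound 4, 1.3-fold (0.10 log units) apart, within the scatter of two such steps

The new compound also gives a second stereo pair, with a 1.5-fold lower number from compound 2 to compound 4 (0.18 log units; within the scatter), so with either ring the drawn configuration at the chain stereocentre gives no step beyond the scatter in this assay: the fact that one of compounds 2 and 4 is drawn with a defined configuration and the other without, at the place where they differ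

The compounds shown leave open how much of the ring step belongs to the methyl group of the 2-amino-4-methyl-1,3-thiazol-5-yl and how much to the rest of that group, which a 2-amino-1,3-thiazol-5-yl group would separate. They also leave open whether the same step holds on a longer chain.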